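This account rests on a few compounds, and the source may have more. Where it says the series, first, only, none or still open, it means among the compounds named here.

Two compounds share one core and differ only in the group on an aromatic carbon of it. Compound 1 `O=Cc1ccc(-c2cn3ccnc3c(-c3ccc4ncn(C5CCCCC5)c4c3)n2)cc1` carries 4-formylphenyl there, and in a functional assay on SK-MEL-5 cells (Homo sapiens) for inhibition, read by sulforhodamine B assay, with a stated time of 48 h, tested at 10 uM (on this read-out lower numbers stand for less inhibition and higher numbers for more inhibition at the one concentration tested (going by the name of the read-out)), compound 1 gives 56.5%. Going by the values given here, compound 2 `c1ccc2c(-c3cn4ccnc4c(-c4ccc5ncn(C6CCCCC6)c5c4)n3)cccc2c1` carries naphthalen-1-yl instead, and in this assay compound 2 gives 4.06%, the lowest of the two numbers seen, with compound 1 as its only neighbour. The measured step of a number 52.4 percentage points lower from compound 1 to compound 2 (beyond the scatter) is the single reference point. Compound 3 `CC(=O)c1ccc(-c2cn3ccnc3c(-c3ccc4ncn(C5CCCCC5)c4c3)n2)cc1` has not yet been measured in this assay. Its change from compound 2 is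

4-acetylphenyl in place of naphthalen-1-yl on an aromatic carbon

The 4-acetylphenyl entering resembles the 4-formylphenyl of compound 1, so the step is expected to run opposite to the measured one, though the size of that step, a number 52.4 percentage points lower from compound 1 to compound 2 (beyond the scatter), need not be matched exactly by an acetyl in place of a formyl. Compound 3 is therefore expected to reach 45% in this assay, within 15% to 65%, an expected step of a number 40.9 percentage points higher from compound 2 to compound 3 (beyond the scatter).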

Compound 3, a percentage reported as inhibition, at one concentration (the size of the read-out at that concentration, not a potency): 24.8%
For compound 3 the middle estimate is 20.2 percentage points above the measured one, within the range that was stated.
By their numbers in this assay, from the lowest: compound 2; then compound 3; then compound 1.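

Even a change as small as methyl in place of hydrogen on the carbonyl carbon matters at this position: in this assay it gives a number 31.7 percentage points lower from compound 1 to compound 3 (beyond the scatter), so the number depends on more than the presence of a phenyl ring bearing a carbonyl. Compound 3 still keeps part of what compound 2 lacks, with 4-acetylphenyl in place of naphthalen-1-yl giving a number 20.7 percentage points higher from compound 2 to compound 3 (beyond the scatter), which places the ketone between the aldehyde of compound 1 and the naphthalen-1-yl of compound 2. Nothing available explains either step.

The compounds shown leave open how a plain phenyl, with no carbonyl at all, would read in this assay. They also leave open where a 4-carboxyphenyl or a 4-aminophenyl would fall, and whether a longer chain on the carbonyl would lower the number further.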